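Stereochemical flip in a small hydroxyamide ester

The source may hold more compounds than are shown below. What is called first, only, known or untested is meant among the compounds shown, and "the series" means these compounds.

Measured compounds:
compound 1 `COC(=O)/C=C\NC(=O)[C@H](O)C(C)(C)CO` — in an ADME assay on HEK293 cells (Homo sapiens) for inhibition, read by CellTiter-Glo, with a stated time of 96 h, tested at 100 uM (on this read-out higher numbers stand for more inhibition at the one concentration tested (going by the name of the read-out) and lower numbers for less inhibition), compound 1 gives "not determined" (no result reported)
compound 2 `COC(=O)/C=C\NC(=O)[C@@H](O)C(C)(C)CO` — -12%

Within the data shown here, compound 2 is the only compound with a number in this assay; compound 1 carries no result there. In this assay compound 2 gives -12%, which on this read-out stands for no measurable inhibition at the single concentration tested. Compounds 1 and 2 have the same atoms and bonds, and the fact that compounds 1 and 2 differ only in the configuration as drawn is the whole of their relationship; with no number for compound 1, nothing can be said of that pair.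

Compound 3 `COC(=O)/C=C/NC(=O)[C@H](O)C(C)(C)CO` is not yet measured. It differs from compound 2 as follows: the two compounds have the same atoms and bonds and differ only in configuration as drawn: 2 of 2 stereo elements differ; a stereocentre at a saturated chain carbon is drawn S in compound 2 and R in compound 3; a double bond is drawn Z in compound 2 and E in compound 3

Among the measured compounds shown here, no step between measured compounds is available to gauge the effect of such a change. With the read-out for compound 2 sitting around zero, the step from compound 2 to compound 3 is expected to be small, most likely none beyond the usual scatter, in either direction: a number 7 percentage points higher from compound 2 to compound 3 (within the scatter). Compound 3 is therefore expected to give about -5% in this assay, within a range from -25% to 15%.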

Compound 3, a percentage reported as inhibition, at one concentration (the size of the read-out at that concentration, not a potency): 0%
Estimate against measurement, compound 3: 5 percentage points below, and the stated range covers the measured number.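

In this assay a change of configuration now has a size, a number 12 percentage points higher from compound 2 to compound 3 (beyond the scatter), whereas the pair of compound 1 and compound 2 gave none. That size has to be read with care: compound 3 at 0% sits at the zero of the read-out, so the step joins two numbers that both stand for no measurable inhibition at the single concentration tested, and changing the stereocentre at the saturated chain carbon and the double bond together did not bring inhibition into view. No atom or bond takes part in this step, so what was tested here is configuration alone: the fact that compounds 2 and 3 differ only in the configuration as drawn

On these data alone, the step changes the stereocentre and the double bond at once, and the steps involving compound 1, which shares its stereocentre with compound 3 and its double bond with compound 2, cannot be read, so the share of each stereo element stays unknown. As far as these compounds go, whether a carboxylic acid or an amine on the shared core would move this assay away from zero also remains open.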